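This account rests on a few compounds, and the source may have more. Where it says the series, first, only, none or still open, it means among the compounds named here.

Working notes on the series. In a functional assay on SW1990 cells (Homo sapiens) for cytotoxicity, read by MTT assay, with a stated time of 48 h (on this read-out lower numbers stand for stronger inhibition and higher numbers for weaker inhibition), compound 1 (`O=C(c1ccc2cccc(OCc3ccc(B(O)O)cc3)c2n1)N1CCC(Oc2no[n+]([O-])c2S(=O)(=O)c2ccccc2)CC1`) gives 12900 nM and compound 2 (`O=C(NCCCOc1no[n+]([O-])c1S(=O)(=O)c1ccccc1)c1ccc2cccc(OCc3ccc(B(O)O)cc3)c2n1`) gives 8830 nM on the same read-out. For the measured compounds named here, these two values lie within the scatter of each other, so compound 2 cannot be separated from the only other measured compound. Compound 3 (`O=C(NCCCOc1no[n+]([O-])c1S(=O)(=O)c1ccccc1)c1ccc2cccc(O)c2n1`) has yet to be measured in this assay and differs from compound 2 by a hydrogen atom in place of a group of 10 heavy atoms (7 carbon, 1 boron, 2 oxygen; one six-membered aromatic ring of carbon only), on an oxygen on an aromatic ring in a single place: a hydrogen atom in place of a group of 10 heavy atoms, on an oxygen on an aromatic ring. Going by the values given here, no measured pair shows this change, so the expectation is a judgement without direct support. A moderate move to a lower number is expected, although a result within the scatter remains possible. The estimated step is a 2.2-fold lower number from compound 2 to compound 3 (0.34 log units; beyond the scatter) in that expected direction. Compound 3 is estimated at 4000 nM with an expected range from 1200 nM to 13000 nM on this measurement.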

Compound 3, half-maximal inhibitory concentration: 9240 nM
Estimate against measurement, compound 3: 2.3-fold (0.36 log units) below; the range from low to high includes it.
By their numbers in this assay, from the lowest: compounds 2, 3 and 1 (each within the scatter of the next).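

In this assay, for the compounds shown here, this pair gives the first reading at the oxygen on an aromatic ring: a hydrogen atom in place of the group of 10 heavy atoms (7 carbon, 1 boron, 2 oxygen) gives a 1.0-fold higher number from compound 2 to compound 3 (0.02 log units; within the scatter). For this pair, the group with its six-membered aromatic ring of carbon only can therefore be exchanged for hydrogen without a difference that this read-out can resolve. Nothing available bears on why the two compounds cannot be separated.

From the compounds shown here alone, it remains open whether a different substituent on this oxygen, such as a methyl group or a chain ending in an amine or a carboxylic acid, would give a step beyond the scatter. Going by these compounds, it is equally open whether the same exchange on the core of compound 1 would give the same result.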